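A few compounds are considered here, and "the series" means these few. Any claim that something is new, unique, unknown or untested is made for them only; others in the source may bear on it.

Going by the values given here, compound 1 `Clc1ccc(Nc2nc3c(N4CCCC4)ncnc3s2)cc1` is one of two compounds measured in an assay on CHO cells for displacement of a labelled ligand from adenosine receptor A3 (Homo sapiens), read by scintillation counting, with a stated time of 3 h; on this read-out lower numbers stand for stronger inhibition and higher numbers for weaker inhibition; compound 1 gives 4260 nM, the highest of the two numbers. Among the compounds with values here, its neighbour compound 2 `Cc1ccc(Nc2nc3c(N4CCCC4)ncnc3s2)cc1` gives 563 nM, and the only step known, a 7.6-fold lower number from compound 1 to compound 2 (0.88 log units; beyond the scatter), concerns the aromatic ring. Compound 3 `OC[C@@H]1CCCN1c1ncnc2sc(Nc3ccc(Cl)cc3)nc12` differs from compound 1 elsewhere: hydroxymethyl in place of hydrogen on a saturated ring carbon. Within the data shown here, no measured step touches this saturated ring, so nothing shows how such a change shifts the numbers. The expectation for compound 3 is therefore a step of a 1.2-fold lower number from compound 1 to compound 3 (0.09 log units; within the scatter), with no shift beyond the scatter. Compound 3 is estimated at 3500 nM, within 900 nM to 14000 nM.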

Compound 3, inhibition constant: 934 nM
Beside the measured number, compound 3's estimate is 3.7-fold (0.57 log units) above it; the measured number falls inside the stated range.
By their numbers in this assay, from the lowest: compounds 2 and 3 (each within the scatter of the next); then compound 1.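

The saturated ring is not a silent part of these molecules: in this assay, hydroxymethyl in place of hydrogen on a saturated ring carbon gives a 4.6-fold lower number from compound 1 to compound 3 (0.66 log units; beyond the scatter), a shift beyond the scatter. Going by these compounds alone, the aromatic ring is therefore no longer the only place where a change is seen to move the number. Nothing available explains this shift.

From the compounds shown here alone, it remains open whether a methyl, a longer hydroxyethyl chain, an aminomethyl or a carboxylic acid on this ring carbon would shift the number in the same way. Going by these compounds, the effect of the mirror-image arrangement of the hydroxymethyl is also open.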